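Removing one methoxy from the ketone aryl of compound 1

The source may report more compounds than this note shows. Statements on the series, on what has been measured and on what is new or still open speak of the compounds shown alone.

Compound 1 `COc1ccc(C(=O)c2ccc3c(ccn3S(=O)(=O)c3cccc(/C=C/C(=O)NO)c3)c2)cc1OC` in an assay on isolated protein for inhibition of protein deacetylase HDAC6 (Homo sapiens) (a lower number here means a stronger inhibitor, a higher number a weaker inhibitor), gives 1180 nM. Among the compounds with values here, that is the highest number among the three compounds measured so far, but compound 2 `COc1ccc(C(=O)c2ccc3c(ccn3S(=O)(=O)c3ccc(/C=C/C(=O)NO)cc3)c2)cc1` gives 848 nM, which lies within the usual scatter of compound 1, so the two cannot be told apart. Within the data shown here, compound 3 `O=C(NO)c1ccc(Cn2ccc3cc(C(=O)c4ccc(F)cc4)ccc32)cc1`, built differently around the shared core, gives 9.25 nM, far beyond the scatter from compound 1 and the only clearly separated number in the set.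

Compound 4 `COc1cccc(C(=O)c2ccc3c(ccn3S(=O)(=O)c3cccc(/C=C/C(=O)NO)c3)c2)c1` has not been measured. It differs from compound 1 in one place: hydrogen in place of methoxy on an aromatic carbon. Among the measured compounds shown here, no measured pair shows this exact change. Compound 2 keeps a single methoxy on the same aryl ketone, and because compound 2 gives 848 nM alongside compound 1, the loss of one methoxy appears to matter little here. The step of a 1.2-fold lower number from compound 1 to compound 4 (0.07 log units; within the scatter) is therefore expected to stay within the scatter, with no direction favoured. Compound 4 is estimated at 1000 nM, with a range from 400 nM to 2500 nM.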

Compound 4, half-maximal inhibitory concentration: 1810 nM
Compound 4: the middle estimate sits 1.8-fold (0.26 log units) below what was measured, and the stated range covers the measured number.
By their numbers in this assay, from the lowest: compound 3; then compounds 2, 1 and 4 (each within the scatter of the next, the first and the last beyond it).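

In this assay, within the data shown here, the change from 3,4-dimethoxyphenyl to 3-methoxyphenyl on the ketone gives a 1.5-fold higher number from compound 1 to compound 4 (0.19 log units; within the scatter) and is the first reading of this change alone. With the rest of compound 1 held fixed, hydrogen can stand in place of this methoxy, on the carbon para to a large group, with no difference that can be told from the scatter; compound 2 differs from compound 1 in more than one place and could not show this. No measurement on hand offers an explanation for this result.

Still open, on these data alone, is whether a different group on this carbon, such as an amine or a carboxylic acid, would move the number beyond the scatter. Also open, as far as these compounds go, is what happens when the remaining methoxy is replaced by hydrogen, leaving a plain phenyl on the ketone.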